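A few compounds are considered here, and "the series" means these few. Any claim that something is new, unique, unknown or untested is made for them only; others in the source may bear on it.

Measured so far: compound 1 `COc1cccc(/C=C/C(=O)c2sc(Nc3ccc(Cl)cc3)nc2C)c1`, compound 2 `COc1cccc(/C=C/C(=O)c2sc(Nc3ccccc3)nc2C)c1`, compound 3 `COc1cccc(/C=C/C(=O)c2sc(Nc3ccccc3C)nc2C)c1`.

Among the measured compounds shown here, in a functional assay on BGC-823 cells (Homo sapiens) for cytotoxicity, read by MTT assay (on this read-out lower numbers stand for stronger inhibition and higher numbers for weaker inhibition), compound 2 gives 14300 nM, the only number. For compound 1 the read-out is a limit, > 25000 nM. For compound 3 it is likewise a limit, > 25000 nM. For the measured compounds named here, compound 2 thus stands as the sole point with a number; an at least 1.7-fold lower number from compound 1 to compound 2 (0.24 log units; that floor lies within the scatter) and an at least 1.7-fold higher number from compound 2 to compound 3 (0.24 log units; that floor lies within the scatter) are floors only, fixed by the limit of > 25000 nM in this assay, at which 2 of the 3 values shown sit, and a step that the two limits leave unreadable from compound 1 to compound 3 is unreadable. Compound 4 `Cc1nc(Nc2ccccc2)sc1C(=O)/C=C/c1ccccc1Cl` differs from compound 2 by 2-chlorophenyl in place of 3-methoxyphenyl on a double-bonded chain carbon bound to a double-bonded chain carbon. All measured steps alter the 4-chlorophenyl, phenyl or 2-methylphenyl on a nitrogen on an aromatic ring; none touches the double-bonded chain carbon changed here. Going by the values given here, with no step bearing on it, the estimated step is no change at the digits printed from compound 2 to compound 4 (within the scatter), none beyond the scatter. Compound 4 is expected at 14300 nM, with a range of 5000 nM to 40000 nM.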

Compound 4, half-maximal inhibitory concentration: 22800 nM
The estimate for compound 4 lay 1.6-fold (0.20 log units) below the measured number; low and high end bracket the measured number.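

At this position, on a double-bonded chain carbon bound to a double-bonded chain carbon, this assay now has a first step: a 1.6-fold higher number from compound 2 to compound 4 (0.20 log units; within the scatter). The exchange of 3-methoxyphenyl for 2-chlorophenyl therefore does not separate the two compounds, and activity in this range is kept with either aromatic ring. This is the only step in the series with a number at both ends, as the others rest on a limit: the limit of > 25000 nM in this assay, at which 2 of the 4 values shown sit.

Still open, as far as these compounds go, is what an amine or a carboxylic acid in place of the 3-methoxyphenyl would give at this position. Also open, from the compounds shown here alone, is whether any group here moves the read-out beyond the scatter from compound 2.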